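Trading the Tertiary Alcohol for a Methyl on a Shared Core

The source may hold more compounds than are shown below. What is called first, only, known or untested is meant among the compounds shown, and "the series" means these compounds.

Of the compounds shown here, three on one shared core have been measured in an ADME assay on microsomes from liver (Homo sapiens) for metabolic stability, with a stated time of 60 min, tested at 1 uM; a higher number here means that more of the compound is left, a lower number that less of the compound is left. Compound 1 `COc1cc(-c2cnn3cc(OC)c(-c4cc(C)no4)nc23)ccn1` gives 31%, and compound 2 `COc1cc(-c2cnn3cc(OC)c(C4CCCC4)nc23)ccn1` gives 32%, two numbers within the scatter of each other. Compound 3 `COc1cc(-c2cnn3cc(OC)c(C(C)(C)O)nc23)ccn1` gives 66%, the highest of the three and beyond the scatter from both others. The two steps leading to it are large: a number 35 percentage points higher from compound 1 to compound 3 (beyond the scatter), and a number 34 percentage points higher from compound 2 to compound 3 (beyond the scatter). Compound 4 `COc1cc(-c2cnn3cc(OC)c(C)nc23)ccn1` differs from compound 3 in one place: methyl in place of 1-hydroxy-1-methylethyl on an aromatic carbon. Both measured steps that bring in the 1-hydroxy-1-methylethyl group show a large rise, so its removal in favour of methyl is expected to give a step back down in this assay, beyond the scatter. The estimate for compound 4 is 40%, with a range from 22% to 60%. This expected change corresponds to a number 26 percentage points lower from compound 3 to compound 4 (beyond the scatter).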

Compound 4, percent of the compound remaining: 44%
Beside the measured number, compound 4's estimate is 4 percentage points below it, within the range that was stated.
By their numbers in this assay, from the lowest: compounds 1 and 2 (each within the scatter of the next); then compound 4; then compound 3.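

At this position in this assay methyl takes a middle place, with a number 22 percentage points lower from compound 3 to compound 4 (beyond the scatter) and also a number 12 percentage points higher from compound 2 to compound 4 (beyond the scatter) and a number 13 percentage points higher from compound 1 to compound 4 (beyond the scatter) as the steps that set it there. Losing the 1-hydroxy-1-methylethyl group therefore does not bring the number back down to the level of the cyclopentyl and 3-methyl-1,2-oxazol-5-yl compounds. Nothing available explains these steps. Still open, from the compounds shown here alone, is whether an amine, a carboxylic acid or a longer chain ending in a hydroxyl group would stand nearer compound 3 or compound 4 on the shared core.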